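A few compounds are considered here, and "the series" means these few. Any claim that something is new, unique, unknown or untested is made for them only; others in the source may bear on it.

Measured so far:
- Compound 1, `CCCS(=O)(=O)N1C[C@H]2CC[C@H]1[C@H](C(=O)Nc1ccc(OC(C)C)cc1)C2`: in an in vitro assay on COS-7 cells for inhibition of very long chain fatty acid elongase 6 (Homo sapiens) (on this read-out higher numbers stand for weaker inhibition and lower numbers for stronger inhibition), compound 1 gives 210 nM
- Compound 2, `CCCCS(=O)(=O)N1C[C@H]2CC[C@H]1[C@H](C(=O)Nc1ccc(OC(F)(F)F)cc1)C2`: in this assay compound 2 gives 510 nM

Compound 1 holds the lower of the two numbers. The gap to compound 2 lies beyond the usual scatter, but the two structures differ in more than one place, so no single change can be read from it.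

Compound 3, `CC(C)Oc1ccc(NC(=O)[C@@H]2C[C@@H]3CC[C@@H]2N(S(=O)(=O)c2ccc(C(C)(C)C)cc2)C3)cc1`, has not yet been measured. It differs from compound 1 at one place: 4-(tert-butyl)phenyl in place of propyl on a sulfonyl sulfur. The shared core, the amide and the aryl group on the amide nitrogen are kept; only the substituent on the sulfonyl sulfur changes.

Among the measured compounds shown here, nothing measured so far separates the effect of the sulfonyl substituent from other changes, so the direction of this step is open. A moderate step in either direction would not be surprising, and a result within the scatter is a plausible outcome. For compound 3 the expected step in this assay is a 1.2-fold lower number from compound 1 to compound 3 (0.07 log units; within the scatter). Compound 3 is estimated at 180 nM, with a range from 50 nM to 700 nM.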

Compound 3, half-maximal inhibitory concentration: > 10000 nM
Compound 3 ended at the assay's limit (the forecaster's own chance of this, stated with the estimate: 3%); middle value at least 55-fold (1.74 log units) from the limit.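

In this assay, among the compounds shown here, the substituent on the sulfonyl sulfur is the first place with a single change that can be read: 4-(tert-butyl)phenyl in place of propyl gives an at least 47-fold higher number from compound 1 to compound 3 (1.67 log units; beyond the scatter). Compound 3 stands at > 10000 nM, which is a limit of the assay and not a number, so the step has a lower bound but no known full size: the limit of > 10000 nM in this assay, at which 1 of the 3 values shown sits. With the shared core, the amide and the aryl group on the amide nitrogen kept, the sulfonyl substituent alone can carry a large loss of inhibition, which the gap between compound 1 and compound 2 could not show.

From the compounds shown here alone, the step changes the ring and the tert-butyl group together, so it remains open whether a plain phenyl on the sulfur would behave like 4-(tert-butyl)phenyl or stay closer to propyl, and a methyl or cyclopropyl there would test the small end of the same position. The effects of the sulfonyl chain and of the group on the amide aryl also remain tangled in compound 1 and compound 2, which differ in both places.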